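The source may hold more compounds than are shown below. What is called first, only, known or untested is meant among the compounds shown, and "the series" means these compounds.

Compound 1 `CN1CCC[C@@H]1Cn1nc(Cc2cccc(F)c2)c2ccccc2c1=O` gives 398 nM in an assay for binding affinity to Alpha-1B adrenergic receptor (Homo sapiens) (on this read-out lower numbers stand for stronger inhibition and higher numbers for weaker inhibition), the highest of the three numbers measured. Compound 2 `CN1CCC[C@@H]1Cn1nc(Cc2ccc(F)cc2)c2ccccc2c1=O` gives 79.4 nM and compound 3 `O=c1c2ccccc2c(Cc2ccc(Cl)cc2)nn1C[C@H]1CCCN1CCCCCc1ccc(OCCCN2CCCCCC2)cc1` gives 50.1 nM in this assay. Within the data shown here, the only single-point step available is a 5.0-fold lower number from compound 1 to compound 2 (0.70 log units; beyond the scatter), where 4-fluorophenyl replaces 3-fluorophenyl. Compound 4 `CCCCCc1nn(C[C@H]2CCCN2C)c(=O)c2ccccc12` differs from compound 1 by butyl in place of 3-fluorophenyl on a saturated chain carbon bound to an aromatic carbon. Among the measured compounds shown here, no measured step matches this change: the step from compound 1 to compound 2 keeps the aromatic ring, and compound 3 differs from both at several places. The expectation for compound 4 therefore rests on little, and a somewhat higher number is estimated, a 2.0-fold higher number from compound 1 to compound 4 (0.30 log units; within the scatter). Compound 4 is expected to give 800 nM in this assay, within a range from 200 nM to 3200 nM.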

Compound 4, inhibition constant: 1000 nM
For compound 4 the middle estimate is 1.3-fold (0.10 log units) below the measured one, and the stated range covers the measured number.
By their numbers in this assay, from the lowest: compounds 3 and 2 (each within the scatter of the next); then compound 1; then compound 4.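

In this assay, butyl on a saturated chain carbon bound to an aromatic carbon gives a higher number than either fluorophenyl group, with (a 2.5-fold higher number from compound 1 to compound 4 (0.40 log units; beyond the scatter)) and a larger change (a 13-fold higher number from compound 2 to compound 4 (1.10 log units; beyond the scatter)). The open chain keeps a measurable number, yet it stands above both ring compounds, so the aromatic ring is favoured over butyl here, more clearly against 4-fluorophenyl than against 3-fluorophenyl. Nothing available explains this difference. As far as these compounds go, whether an unsubstituted phenyl, a cyclohexyl ring or a longer chain would match the fluorophenyl groups or butyl remains open.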